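From amino to diacetylamino on compound 1

A few compounds are considered here, and "the series" means these few. Any claim that something is new, unique, unknown or untested is made for them only; others in the source may bear on it.

For the measured compounds named here, in a functional assay on PC-3 cells (Homo sapiens) for cytotoxicity, read by MTT assay, with a stated time of 48 h (a higher number here means a weaker inhibitor, a lower number a stronger inhibitor), compound 1 `COc1ccc(-c2c(-c3cc(OC)c(OC)c(OC)c3)noc2N)cc1` gives 3030 nM as the lowest of the two numbers known so far. Going by the values given here, its only measured neighbour, compound 2 `COc1ccc(-c2c(-c3cc(OC)c(OC)c(OC)c3)noc2N)cc1OC`, gives 21100 nM with one added methoxy in place of hydrogen on an aromatic carbon. That change amounts to a 7.0-fold higher number from compound 1 to compound 2 (0.84 log units; beyond the scatter) and lies beyond the scatter.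

Compound 3 `COc1ccc(-c2c(-c3cc(OC)c(OC)c(OC)c3)noc2N(C(C)=O)C(C)=O)cc1` keeps the core of compound 1 but carries diacetylamino in place of amino on an aromatic carbon, next to the ring oxygen. The counted difference is diacetylamino in place of amino on an aromatic carbon in all. Among the compounds with values here, no measured step touches this place, so the evidence is thin. Within the data shown here, the one guide is the change from compound 1 to compound 2, where a 7.0-fold higher number from compound 1 to compound 2 (0.84 log units; beyond the scatter) shows that a single added group can raise the number. A step of similar or somewhat smaller size toward a higher number is therefore expected in this assay, though a much smaller one cannot be excluded. The estimate is a 3.0-fold higher number from compound 1 to compound 3 (0.47 log units; beyond the scatter) as the expected step. Compound 3 is expected at about 9000 nM within an estimated range from 1800 nM to 45000 nM in this measurement.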

Compound 3, half-maximal inhibitory concentration: 360 nM
The estimate for compound 3 lay 25-fold (1.40 log units) above the measured number, outside the stated range (below it).
By their numbers in this assay, from the lowest: compound 3; then compound 1; then compound 2.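

In this assay, the amino group of compound 1 turns out not to be needed for a low number: replacing it with diacetylamino on the same aromatic carbon gives an 8.4-fold lower number from compound 1 to compound 3 (0.93 log units; beyond the scatter) and lies beyond the scatter. The substituent at this place can therefore lose the hydrogen-bond donor of the amino group and become a much larger group, with two carbonyls, while the number still falls. Until now the only step known, a 7.0-fold higher number from compound 1 to compound 2 (0.84 log units; beyond the scatter), ran upward at another place on the core, so this is the first change shown to move the number downward, and nothing available gives a reason for the fall at this position.

The compounds shown do not separate the contribution of the first acetyl group from that of the second, so a monoacetylamino group, a methylamino group or a longer acyl chain such as propionyl would be needed to tell how much of the step each part of the new group carries. On these data alone, whether diacetylamino gives a step of similar size on compound 2, with its added methoxy, also remains open.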